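Shifting Two Fluorines on the Acyl Phenyl Ring

The source may hold more compounds than are shown below. What is called first, only, known or untested is meant among the compounds shown, and "the series" means these compounds.

Three compounds sharing one core have been measured in a functional assay on HEK293 cells for positive allosteric modulation of metabotropic glutamate receptor 5 (Homo sapiens), read by calcium flux; on this read-out lower numbers stand for smaller maximal responses and higher numbers for larger maximal responses:

compound 1 `O=C(c1ccc(F)cc1)N1CCc2nc(COc3cccc(F)c3)oc2C1`: 78%
compound 2 `O=C(c1cccc(F)c1F)N1CCc2nc(COc3cccc(F)c3)oc2C1`: 72%
compound 3 `O=C(c1ccc(F)c(F)c1)N1CCc2nc(COc3cccc(F)c3)oc2C1`: 71%

Compound 3 carries the lowest of the three numbers, but the steps of a number 1 percentage points lower from compound 2 to compound 3 (within the scatter) and a number 7 percentage points lower from compound 1 to compound 3 (within the scatter) both fall within the scatter, so the three compounds cannot be ranked against each other on these data.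

Compound 4 `O=C(c1c(F)cccc1F)N1CCc2nc(COc3cccc(F)c3)oc2C1` differs from compound 3 only on the acyl side: 2,6-difluorophenyl in place of 3,4-difluorophenyl on a carbonyl carbon

For the measured compounds named here, two measured steps bear on this change, since each of them also moves fluorines around the phenyl ring on the carbonyl carbon while the rest of the molecule stays the same. The step of a number 6 percentage points lower from compound 1 to compound 2 (within the scatter) and the step of a number 1 percentage points lower from compound 2 to compound 3 (within the scatter) are both within the scatter, as is a number 7 percentage points lower from compound 1 to compound 3 (within the scatter). Every rearrangement of fluorines on that ring seen so far has left the maximal response essentially unchanged, and compound 4 is expected to behave the same way, with a step of a number 1 percentage points higher from compound 3 to compound 4 (within the scatter) that lies within the scatter.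

Compound 4 is therefore estimated to give 72% in this assay, with a plausible range from 58% to 86%.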

Compound 4, largest response reached (reported as percent of maximum), in percent of the reference or control that the assay uses: 82%
Compound 4: middle estimate off by 10 percentage points, on the low side; measured number inside the range.
By their numbers in this assay, from the lowest: compounds 3, 2, 1 and 4 (each within the scatter of the next, the first and the last beyond it).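

Placing the fluorines as 2,6-difluorophenyl on the carbonyl carbon gives the only step in this set that clears the scatter in this assay, with a number 11 percentage points higher from compound 3 to compound 4 (beyond the scatter) as the change from the 3,4-difluorophenyl group, so this position is not wholly indifferent to how the two fluorines are arranged. The separation is narrow, however, since a number 10 percentage points higher from compound 2 to compound 4 (within the scatter) and a number 4 percentage points higher from compound 1 to compound 4 (within the scatter) both remain inside the scatter, which means compound 4 stands apart only from compound 3 and cannot be ranked against compound 2 or compound 1. Nothing available speaks to what lies behind the difference between these two difluorophenyl groups.

The compounds shown leave open whether a plain phenyl ring, or a methoxy group or a nitrile in place of the fluorines, would keep the maximal response of compound 4 on this carbonyl carbon. They also leave open whether the gap between the 2,6-difluorophenyl and 3,4-difluorophenyl groups persists when the rest of the molecule carries a different ether side chain.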